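Furan-to-thiophene amide swap on the ether side chain

A few compounds are considered here, and "the series" means these few. Any claim that something is new, unique, unknown or untested is made for them only; others in the source may bear on it.

Measured compounds in a functional assay on PANC-1 cells (Homo sapiens) for inhibition, read by MTT assay, with a stated time of 24 h, tested at 10 uM; on this read-out lower numbers stand for less inhibition and higher numbers for more inhibition at the one concentration tested (going by the name of the read-out):
compound 1, `CC(C)=CCC1Cc2c(OCc3ccccc3)cc(=O)n(CCCO)c2CC1(C)C`: -0.3%
compound 2, `CC(C)=CCC1Cc2c(OCCCNC(=O)c3ccco3)cc(=O)n(CCCO)c2CC1(C)C`: 2.1%

Both measured compounds sit at the bottom of the read-out in this assay. Compound 2 holds the higher of the two numbers, but the gap to compound 1, a number 2.4 percentage points higher from compound 1 to compound 2 (within the scatter), lies within the scatter, so the two cannot be ordered; neither shows inhibition of note at the one concentration tested.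

The next compound, compound 3, `CC(C)=CCC1Cc2c(OCCCNC(=O)c3cccs3)cc(=O)n(CCCO)c2CC1(C)C`, carries the change (thiophen-2-yl in place of furan-2-yl on a carbonyl carbon). Among the compounds with values here, no measured step touches the aromatic ring on the amide carbonyl; the only step in hand, from compound 1 to compound 2, exchanges the whole side chain and was itself within the scatter. There is therefore nothing in the measured pairs that points to a shift in either direction for this swap.

The expectation for compound 3 is a step of a number 0.1 percentage points lower from compound 2 to compound 3 (within the scatter) in this assay, that is, no change beyond the scatter. The estimated value for compound 3 is 2%, with a range from -8% to 12%.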

Compound 3, a percentage reported as inhibition, at one concentration (the size of the read-out at that concentration, not a potency): 33.6%
Beside the measured number, compound 3's estimate is 31.6 percentage points below it, outside the stated range (above it).
By their numbers in this assay, from the lowest: compounds 1 and 2 (each within the scatter of the next); then compound 3.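

In this assay, the aromatic ring on the amide carbonyl turns out to be a place where the read-out responds strongly: thiophen-2-yl in place of furan-2-yl gives a number 31.5 percentage points higher from compound 2 to compound 3 (beyond the scatter) even though the two groups match in heavy atoms, ring size and hydrogen-bond counts, with sulfur standing for oxygen. The amide side chain alone therefore does not settle the result, since its furan form stayed within the scatter of the benzyl ether of compound 1, whereas its thiophene form gives a number 33.9 percentage points higher from compound 1 to compound 3 (beyond the scatter) in the same assay. Nothing at hand explains this gain, which stands as an observation only.

Open, as far as these compounds go, is whether the gain is specific to thiophen-2-yl or would carry over to a phenyl or a pyridin-3-yl on the amide carbonyl, and whether it would survive a longer chain on the ether oxygen. A single concentration also gives the size of the inhibition only, so the potency of compound 3 and any dependence on dose remain undefined.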